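Swapping the Chain-End Amine on a Chromone Scaffold

This account rests on a few compounds, and the source may have more. Where it says the series, first, only, none or still open, it means among the compounds named here.

Compound 2 `CN1CCN(CCCOc2c(OCc3ccccc3)cc3oc(-c4ccccc4)cc(=O)c3c2O)CC1` carries a 4-methylpiperazin-1-yl group on a saturated chain carbon, three bonds along the chain from an oxygen on an aromatic ring. Among the measured compounds shown here, in a functional assay on A549 cells (Homo sapiens) for antiproliferative activity, read by MTT assay, with a stated time of 48 h (on this read-out higher numbers stand for weaker inhibition and lower numbers for stronger inhibition), compound 2 gives 1300 nM, the lower of the two numbers measured so far, although the gap to its only neighbour is within the scatter. That neighbour, compound 1 `CCN(CC)CCCCOc1c(OCc2ccccc2)cc2oc(-c3ccccc3)cc(=O)c2c1O`, gives 1800 nM in this assay. For the measured compounds named here, the single measured step, a 1.4-fold lower number from compound 1 to compound 2 (0.14 log units; within the scatter), exchanges one amine for another at the same chain position and does not move the number beyond the scatter.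

Compound 3 `CN(C)CCCOc1c(OCc2ccccc2)cc2oc(-c3ccccc3)cc(=O)c2c1O` differs from compound 2 in one place: dimethylamino in place of 4-methylpiperazin-1-yl on a saturated chain carbon, three bonds along the chain from an oxygen on an aromatic ring. Going by the values given here, this is the same kind of exchange as the one measured step, a different amine at the end of the same chain, and that step was small. One therefore expects no shift beyond the scatter, with an estimated step of a 1.2-fold higher number from compound 2 to compound 3 (0.06 log units; within the scatter). For compound 3 in this assay the estimated value is 1500 nM, with a range from 700 nM to 3500 nM.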

Compound 3, half-maximal inhibitory concentration: 2600 nM
Estimate against measurement, compound 3: 1.7-fold (0.24 log units) below, within the range that was stated.
By their numbers in this assay, from the lowest: compounds 2, 1 and 3 (each within the scatter of the next).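

In this assay, the step of a 2.0-fold higher number from compound 2 to compound 3 (0.30 log units; within the scatter) removes the whole ring of 4-methylpiperazin-1-yl, with 7 heavy atoms and 2 nitrogens, and puts dimethylamino, with 3 heavy atoms and no ring, in its place, yet it stays within the scatter. The other new step, a 1.4-fold higher number from compound 1 to compound 3 (0.16 log units; within the scatter), replaces (diethylamino)methyl with dimethylamino and is also within the scatter, so across these three compounds neither the ring nor the larger acyclic group separates the numbers at this position. No other measurement accompanies these numbers, so the result cannot be tied to any property of the groups.

As far as these compounds go, what a piperidine or a morpholine would give at the end of the same chain stays open, as does the effect of a carboxylic acid or a simple hydroxyl group there in place of an amine. Also open is how dimethylamino or 4-methylpiperazin-1-yl would behave on a longer chain, since each of these two groups is shown on only one chain, 3-(dimethylamino)propyl and 3-(4-methylpiperazin-1-yl)propyl.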